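Urea tail swap on the shared core: compound 4

The source may report more compounds than this note shows. Statements on the series, on what has been measured and on what is new or still open speak of the compounds shown alone.

In a functional assay on A-431 cells (Homo sapiens) for antiproliferative activity, read by MTT assay, with a stated time of 72 h (a higher number here means a weaker inhibitor, a lower number a stronger inhibitor), compound 2 `CCN(CC)Cc1ccc(NC(=O)Nc2ccc3ncnc(Nc4cccc(C(F)(F)F)c4)c3c2)cc1` gives 3980 nM, the second highest of the three numbers. Its nearest neighbour, compound 1 `COC(=O)c1cccc(Nc2ncnc3ccc(NC(=O)Nc4ccc(CN5CCN(C)CC5)cc4)cc23)c1`, gives 5630 nM, a gap within the scatter, so no order between the two is claimed. Compound 3 `C#Cc1cccc(Nc2ncnc3ccc(NC(=O)Nc4ccc(CN(CC)CC)cc4)cc23)c1` gives 1240 nM and lies furthest from compound 2. Among the measured compounds shown here, the one measured step, a 3.2-fold lower number from compound 2 to compound 3 (0.51 log units; beyond the scatter), concerns the group on the aromatic carbon, not the urea side. Compound 4 `CN1CCN(CCNC(=O)Nc2ccc3ncnc(Nc4cccc(C(F)(F)F)c4)c3c2)CC1` differs from compound 2 by 2-(4-methylpiperazin-1-yl)ethyl in place of 4-((diethylamino)methyl)phenyl on an amide-type nitrogen. For the measured compounds named here, no measured step touches this position, so nothing measured bears on the change directly. A step of uncertain direction, likely no larger than the one seen so far, is expected: a 1.8-fold higher number from compound 2 to compound 4 (0.25 log units; within the scatter). Compound 4 is estimated at 7000 nM, with a range from 1800 nM to 28000 nM.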

Compound 4, half-maximal inhibitory concentration: > 10000 nM
Compound 4: only a limit was reported; the forecaster's own chance of this, stated with the estimate: 15%; middle value at least 1.4-fold (0.15 log units) away from the limit.
By their numbers in this assay, from the lowest: compound 3; then compounds 2 and 1 (each within the scatter of the next). At a limit, above all of these: compound 4.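

In this assay, compound 4 gives > 10000 nM, a limit of the assay and not a number. The urea side now has a measured step, an at least 2.5-fold higher number from compound 2 to compound 4 (0.40 log units; beyond the scatter), so this position does respond to a change of tail. Only one side of that step is fixed: the limit of > 10000 nM in this assay, at which 1 of the 4 values shown sits.

The change replaces the aromatic ring and the chain together, so the compounds shown do not separate the two. On these data alone, a 2-(diethylamino)ethyl group on the same amide-type nitrogen would keep the amine of compound 2 on the chain of compound 4, and its effect remains open.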